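This account rests on a few compounds, and the source may have more. Where it says the series, first, only, none or still open, it means among the compounds named here.

Compound 3 `COc1ccc(Cn2cc(C[N+](C)(C)C)c3ccccc32)cc1O` gives 9500 nM in an assay on HEK293 cells for antagonist activity at Neuronal acetylcholine receptor; alpha4/beta2 (Homo sapiens), read by calcium flux (on this read-out higher numbers stand for weaker inhibition and lower numbers for stronger inhibition), the smallest number shown, yet the gap to compound 1 sits within the scatter and only the gap to compound 2 exceeds it. Compound 1 `C[N+](C)(C)Cc1cn(Cc2cccc(O)c2)c2ccccc12` gives 14700 nM, and compound 2 `C[N+](C)(C)Cc1cn(Cc2ccc(O)cc2)c2ccccc12` gives 24900 nM. The steps of a 1.5-fold lower number from compound 1 to compound 3 (0.19 log units; within the scatter) and a 1.7-fold higher number from compound 1 to compound 2 (0.23 log units; within the scatter) both stayed within the scatter, so changes on this phenyl ring have so far moved the numbers little. Compound 4 `COc1ccc(Cn2cc(C[N+](C)(C)C)c3ccccc32)cc1OC` differs from compound 3 by methyl in place of hydrogen on an oxygen on an aromatic ring. Among the compounds with values here, no measured pair tests exactly this exchange; the nearest comparison, the change from compound 1 to compound 3 on the same ring, was small. A step of about a 1.3-fold higher number from compound 3 to compound 4 (0.10 log units; within the scatter) is therefore expected, not beyond the scatter. Compound 4 is estimated to give 12000 nM, with a likely range from 5000 nM to 30000 nM.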

Compound 4, half-maximal inhibitory concentration: 14800 nM
Compound 4: the middle estimate sits 1.2-fold (0.09 log units) below what was measured, and the stated range covers the measured number.
By their numbers in this assay, from the lowest: compounds 3, 1, 4 and 2 (each within the scatter of the next, the first and the last beyond it).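

Replacing the hydroxy group of compound 3 with methoxy on this oxygen on an aromatic ring gives only a small step (a 1.6-fold higher number from compound 3 to compound 4 (0.19 log units; within the scatter)). Compound 4 has no hydroxy group on this ring, yet its number stays within the scatter of that of compound 3, so this hydrogen is not needed to keep the number in this range. Nothing available explains why this exchange changes so little. Going by these compounds, whether a longer chain on this oxygen, as in ethoxy, or an amine in its place would do the same remains open.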